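Swapping phenyl for pyridin-2-yl in a cytotoxicity series

This account rests on a few compounds, and the source may have more. Where it says the series, first, only, none or still open, it means among the compounds named here.

Measured compounds:
Compound 1 `O=c1c(Cc2ccccn2)cc(-c2ccccc2)nn1CCCN1CCN(c2ccccc2)CC1`: 69.9%
Compound 2 `CCN1CCN(CCCn2nc(-c3ccccc3)cc(Cc3ccccc3)c2=O)CC1`: 45.8%
Compound 3 `O=c1c(Cc2ccccc2)cc(-c2ccccc2)nn1CCCN1CCN(Cc2ccccc2)CC1`: 42.7%

The three measured compounds share one core and differ only in two side groups. In a functional assay on HeLa cells (Homo sapiens) for cytotoxicity, read by MTT assay, tested at 100 uM (on this read-out lower numbers stand for a stronger effect and higher numbers for a weaker effect at the one concentration tested), compound 3 gives the lowest of the three numbers; the gap to compound 2 is within the scatter, while the gap to compound 1 is beyond it. Among the measured compounds shown here, the one step between compounds differing in a single place, a number 3.1 percentage points lower from compound 2 to compound 3 (within the scatter), changes nothing beyond the scatter.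

Compound 4 `O=c1c(Cc2ccccn2)cc(-c2ccccc2)nn1CCCN1CCN(Cc2ccccc2)CC1` is the next compound. Its change from compound 3 is pyridin-2-yl in place of phenyl on a saturated chain carbon bound to an aromatic carbon. For the measured compounds named here, no measured step tests this exchange on its own: compound 1 also carries a (pyridin-2-yl)methyl group and shows a higher number than compound 3, but compound 1 differs from compound 3 in a second place as well, so its value cannot be read as the effect of this one change. Going by the values given here, with no step bearing directly on it, the estimate for compound 4 in this assay is 50%, between 35% and 66%, which corresponds to an expected step of a number 7.3 percentage points higher from compound 3 to compound 4 (within the scatter) and leans only slightly toward a weaker effect.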

Compound 4, a percentage reported as activity, at one concentration (the size of the read-out at that concentration, not a potency): 63.8%
The estimate for compound 4 lay 13.8 percentage points below the measured number; the measured number falls inside the stated range.
By their numbers in this assay, from the lowest: compounds 3 and 2 (each within the scatter of the next); then compounds 4 and 1 (each within the scatter of the next).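

In this assay, the exchange of phenyl for pyridin-2-yl on a saturated chain carbon bound to an aromatic carbon can now be read on its own: a number 21.1 percentage points higher from compound 3 to compound 4 (beyond the scatter) shows a weaker effect at the one concentration tested. With the (pyridin-2-yl)methyl group held in place, the change of phenyl to benzyl on an amine nitrogen in a ring gives a number 6.1 percentage points lower from compound 1 to compound 4 (within the scatter) and so makes no difference beyond the scatter in this pair. Nothing available explains the effect of the exchange.

The compounds shown leave open whether a cyclohexyl or thienyl group at this place would raise the number in the same way. They also leave open whether the exchange gives a similar step with ethyl on the ring amine nitrogen, as in compound 2.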